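Working notes: from compound 2 to compound 3

The source may hold more compounds than are shown below. What is called first, only, known or untested is meant among the compounds shown, and "the series" means these compounds.

Measured in a physicochemical assay for solubility, read by chemiluminescence, measured as kinetic solubility; on this read-out higher numbers stand for higher solubility and lower numbers for lower solubility:
- compound 1 `O=C(C1CCCN1)N1CCC2(CCN(c3nccc(NCc4ccc(Cl)cc4Cl)n3)CC2)C1`: 79 ug/mL
- compound 2 `O=C(C1CCCN1)N1CCC2(CCN(c3nccc(NCc4ccc(F)cc4F)n3)CC2)C1`: 175 ug/mL

Within the data shown here, compound 2 holds the higher of the two numbers so far. The next structure, compound 3 `CN(Cc1ccc(Cl)cc1Cl)c1ccnc(N2CCC3(CCN(C(=O)C4CCCN4)C3)CC2)n1`, is not yet measured. The change is (2,4-dichlorobenzyl)(methyl)amino in place of (2,4-difluorobenzyl)amino on an aromatic carbon.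

Among the measured compounds shown here, one measured step bears on this change: a 2.2-fold higher number from compound 1 to compound 2 (0.35 log units; beyond the scatter). Compound 3 carries the same dichloro-substituted aromatic ring as compound 1, so that step is read in reverse, toward a lower number. Compound 1, at 79 ug/mL, is the closest reference. For the measured compounds named here, no measured step covers the added methyl, and this widens the range.

In this assay the expectation is a modest drop, estimated as a 2.5-fold lower number from compound 2 to compound 3 (0.40 log units; beyond the scatter). For compound 3 the expected value is 70 ug/mL, with an estimated range of 30 ug/mL to 160 ug/mL.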

Compound 3, solubility: 190 ug/mL
Beside the measured number, compound 3's estimate is 2.7-fold (0.43 log units) below it; the whole stated range lies below it.
By their numbers in this assay, from the lowest: compound 1; then compounds 2 and 3 (each within the scatter of the next).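

In this assay, with the 2,4-dichlorobenzyl group held constant, methyl in place of hydrogen on the nitrogen on the aromatic ring gives a 2.4-fold higher number from compound 1 to compound 3 (0.38 log units; beyond the scatter), so this nitrogen is a position where a single added methyl moves the number beyond the scatter. The full exchange of (2,4-difluorobenzyl)amino for (2,4-dichlorobenzyl)(methyl)amino on the aromatic carbon gives a 1.1-fold higher number from compound 2 to compound 3 (0.04 log units; within the scatter), which shows that the dichloro ring can sit in a compound whose number is within the scatter of that of compound 2. Nothing measured on these compounds accounts for either step.

The compounds shown leave open whether the methyl gives a step of similar size when the ring carries 2,4-difluoro substitution. Also open, going by these compounds, is how an ethyl group or a longer chain on the same nitrogen would compare with the methyl.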